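The source may hold more compounds than are shown below. What is called first, only, known or untested is meant among the compounds shown, and "the series" means these compounds.

Compound 3 `COc1cc(N)c(Cl)cc1C(=O)NC1CCN(CCCCCN2CCCCC2)CC1` stands lowest of the three numbers measured in an assay on HEK293 cells for displacement of a labelled ligand from 5-hydroxytryptamine receptor 4 (Homo sapiens), read by scintillation counting (on this read-out higher numbers stand for weaker inhibition and lower numbers for stronger inhibition), where compound 3 gives 10 nM. Compound 1 `CCCCCN1CCC(NC(=O)c2cc(Cl)c(N)cc2OC)CC1` gives 100 nM in this assay, and compound 2 `COc1cc(N)c(Cl)cc1C(=O)NC1CCN(CCCCCCCCO)CC1` gives 79.4 nM. The measured steps are a 10-fold lower number from compound 1 to compound 3 (1.00 log units; beyond the scatter), a 7.9-fold lower number from compound 2 to compound 3 (0.90 log units; beyond the scatter) and a 1.3-fold lower number from compound 1 to compound 2 (0.10 log units; within the scatter).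

Compound 4 `COc1cc(N)c(Cl)cc1C(=O)NC1CCN(CCCCCCCCN2CCCCC2)CC1` has not yet been measured. It differs from compound 3 by 3-(piperidin-1-yl)propyl in place of piperidin-1-yl on a saturated chain carbon, five bonds along the chain from an amine nitrogen in a ring. For the measured compounds named here, the steps that bear on this change are the two that brought the piperidin-1-yl group in, a 10-fold lower number from compound 1 to compound 3 (1.00 log units; beyond the scatter) and a 7.9-fold lower number from compound 2 to compound 3 (0.90 log units; beyond the scatter), which show that the terminal ring matters, and the step of a 1.3-fold lower number from compound 1 to compound 2 (0.10 log units; within the scatter), which shows that lengthening the chain on its own stayed within the scatter. Since compound 4 keeps the ring and only lengthens the chain, no step beyond the scatter is expected in this assay.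

Compound 4 is therefore expected to give 12 nM, within a range from 4 nM to 40 nM. The expected step is a 1.2-fold higher number from compound 3 to compound 4 (0.08 log units; within the scatter).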

Compound 4, inhibition constant: 3.16 nM
The estimate for compound 4 lay 3.8-fold (0.58 log units) above the measured number; measured number outside the range, below it.
By their numbers in this assay, from the lowest: compound 4; then compound 3; then compounds 2 and 1 (each within the scatter of the next).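

In this assay, lengthening the chain changes the result once the terminal piperidin-1-yl ring is present: 3-(piperidin-1-yl)propyl in place of piperidin-1-yl gives a step beyond the scatter (a 3.2-fold lower number from compound 3 to compound 4 (0.50 log units; beyond the scatter)), which the ring-free chain change had not shown. At the end of the longer chain, piperidin-1-yl in place of hydroxy gives a large step (a 25-fold lower number from compound 2 to compound 4 (1.40 log units; beyond the scatter)), and the full 3-(piperidin-1-yl)propyl group in place of hydrogen also gives a large one (a 32-fold lower number from compound 1 to compound 4 (1.50 log units; beyond the scatter)), so the terminal ring and the added chain length together account for the lowest number in the series. No evidence is available on what lies behind these steps.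

As far as these compounds go, it remains open whether a still longer chain would lower the number further or reverse the gain. From the compounds shown here alone, it is also open whether a terminal morpholine or dimethylamino group could take the place of piperidin-1-yl on this chain.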